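This account rests on a few compounds, and the source may have more. Where it says the series, first, only, none or still open, it means among the compounds named here.

Of the compounds shown here, three sharing one core have been measured in a functional assay on MCF7 cells (Homo sapiens) for cytotoxicity, read by MTT assay, with a stated time of 96 h; a lower number here means a stronger inhibitor, a higher number a weaker inhibitor. Compound 1 `COc1cc(C(=O)c2cn(-c3ccc(C)cc3)cc2-c2ccccc2[N+](=O)[O-])cc(OC)c1OC` gives 65 nM, compound 2 `COc1cc(C(=O)c2cn(-c3ccc(C)cc3)cc2-c2cccc(N)c2)cc(OC)c1OC` gives 53 nM, and compound 3 `COc1cc(C(=O)c2cn(-c3ccc(C)cc3)cc2-c2ccc(N)cc2)cc(OC)c1OC` gives 6 nM. Compound 2 sits at the weaker end of this small set alongside compound 1, with a 1.2-fold lower number from compound 1 to compound 2 (0.09 log units; within the scatter). Compound 3 stands clearly apart, with an 8.8-fold lower number from compound 2 to compound 3 (0.95 log units; beyond the scatter) and an 11-fold lower number from compound 1 to compound 3 (1.03 log units; beyond the scatter).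

The next compound, compound 4 `COc1cc(C(=O)c2cn(-c3ccc(F)cc3)cc2-c2cccc(N)c2)cc(OC)c1OC`, keeps the 3-aminophenyl group of compound 2 and differs elsewhere: fluoro in place of methyl on an aromatic carbon. This is fluoro in place of methyl on an aromatic carbon, or 4-methylphenyl to 4-fluorophenyl. Among the compounds with values here, none of the measured steps touches this position, since all three change only the phenyl group carrying the nitro or amino substituent. They therefore give no direct guide to the size or direction of this step. Within the data shown here, they do serve as a warning, though: the single change in an 8.8-fold lower number from compound 2 to compound 3 (0.95 log units; beyond the scatter) shows that one small edit can shift the number considerably, so the range should stay wide. With no evidence for a real shift, the expected step is a 1.1-fold higher number from compound 2 to compound 4 (0.05 log units; within the scatter), which would be no change beyond the scatter. For compound 4 the estimated value is 60 nM, with an expected range of 20 nM to 180 nM.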

Compound 4, half-maximal inhibitory concentration: 53 nM
Compound 4: middle estimate off by 1.1-fold (0.05 log units), on the high side; measured number inside the range.
By their numbers in this assay, from the lowest: compound 3; then compounds 2, 4 and 1 (each within the scatter of the next).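

In this assay, within the data shown here, the change from 4-methylphenyl to 4-fluorophenyl gives no change at the digits printed from compound 2 to compound 4 (within the scatter), and this is the first step in the set that touches this position, since all the earlier steps changed only the other phenyl group. With the 3-aminophenyl group held in place, replacing methyl with fluoro on this aromatic carbon leaves the number where it was, whereas moving the amino group on the other phenyl ring gave an 8.8-fold lower number from compound 2 to compound 3 (0.95 log units; beyond the scatter). So, for this one pair, the position accepts a swap of one heavy atom for another without any shift beyond the usual scatter, though a single pair cannot show how the position behaves in general, and no measurement of any property of these compounds speaks to the result.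

The compounds shown leave open whether the same swap would also make no difference alongside the 4-aminophenyl group of compound 3, which gives 6 nM. They also leave open what a larger or quite different group at this position would do, such as a methoxy group, a carboxylic acid or a longer alkyl chain.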